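Ring size on the thiocarbonyl nitrogen across two cores

The source may hold more compounds than are shown below. What is called first, only, known or untested is meant among the compounds shown, and "the series" means these compounds.

Compound 1 `Cc1ccc2c(=O)c(CSC(=S)N3CCCCC3)coc2c1`: > 25000 nM
Compound 2 `Cc1ccc2c(=O)c(CSC(=S)N3CCCC3)coc2c1`: 4400 nM
Compound 3 `CCOC(=O)c1cc(=O)c2cc(CSC(=S)N3CCCC3)ccc2o1`: 6600 nM

Of the compounds shown here, three have been measured in a functional assay on HeLa cells (Homo sapiens) for antiproliferative activity, read by MTT assay, with a stated time of 72 h; on this read-out higher numbers stand for weaker inhibition and lower numbers for stronger inhibition. Compound 2 gives 4400 nM. Compound 1 gives only a limit of this assay, > 25000 nM, and no number (the limit of > 25000 nM in this assay, at which 1 of the 3 values shown sits). The two differ in one place: piperidin-1-yl in place of pyrrolidin-1-yl on a thiocarbonyl carbon. That change produced an at least 5.6-fold higher number from compound 2 to compound 1 (0.75 log units; beyond the scatter).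

Compound 3 gives 6600 nM in this assay, which sits within the scatter of the value of compound 2. How the core of compound 3 differs from the core of compound 2 is not broken down here.

Compound 4 `CCOC(=O)c1cc(=O)c2cc(CSC(=S)N3CCCCC3)ccc2o1` is not yet measured. It stands to compound 3 as compound 1 stands to compound 2: piperidin-1-yl in place of pyrrolidin-1-yl on a thiocarbonyl carbon. The place lines of the two changes read the same, so this is the same kind of change on a different core. Resting on the step from compound 2 to compound 1, the step from compound 3 to compound 4 is expected to be a 5.3-fold higher number from compound 3 to compound 4 (0.72 log units; beyond the scatter). Compound 4 is therefore estimated at 35000 nM, somewhere between 12000 nM and 100000 nM, with a fair chance that this assay again reports only a limit.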

Compound 4, half-maximal inhibitory concentration: 5800 nM
For compound 4 the middle estimate is 6.0-fold (0.78 log units) above the measured one; measured number below the stated range.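

On the core of compound 3, piperidin-1-yl in place of pyrrolidin-1-yl on a thiocarbonyl carbon gives in this assay a 1.1-fold lower number from compound 3 to compound 4 (0.06 log units; within the scatter), so here the change leaves the read-out within the scatter. The step seen on the core of compound 2 therefore did not carry over to the core of compound 3, and the two steps differ: the same change on two cores in this assay, an at least 5.6-fold higher number (0.75 log units; beyond the scatter) from compound 2 to compound 1 and a 1.1-fold lower number (0.06 log units; within the scatter) from compound 3 to compound 4, at least 6.4-fold (0.81 log units) apart, beyond the scatter of two such steps. This does not show which difference between the two cores is at work, nor the full size of the earlier step: compound 1 gives only a limit, > 25000 nM.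

Going by these compounds, with just one pair on each core, it remains open whether either behaviour extends to other groups on the thiocarbonyl carbon, such as morpholin-4-yl or diethylamino. Also open, on these data alone, is how the change would fare on further cores, for instance with a carboxylic acid in place of the ethyl ester of compound 3.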